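A few compounds are considered here, and "the series" means these few. Any claim that something is new, unique, unknown or untested is made for them only; others in the source may bear on it.

Compound 1 `COc1cc(O)c(C(=O)/C=C/c2ccc(F)cc2)c(OC)c1` gives > 20000 nM as a limit
Compound 2 `COc1cc(OC)c(C(=O)/C=C/c2ccccc2SC)c(OC)c1` gives 14100 nM as a number

For the measured compounds named here, in a functional assay on Huh-7 cells (Homo sapiens) for cytotoxicity, with a stated time of 48 h (on this read-out higher numbers stand for weaker inhibition and lower numbers for stronger inhibition), compound 2 gives 14100 nM as the only actual number so far. Compound 1 stands at > 20000 nM which is a limit and not a number. Compound 3 `COc1cc(OC)c(C(=O)/C=C/c2ccccc2)c(OC)c1` differs from compound 2 by one change hydrogen in place of methylsulfanyl on an aromatic carbon with hydrogen in place of methylsulfanyl on an aromatic carbon, ortho to a large group. Going by the values given here, no measured pair shows this change, so in this assay nothing beyond the scatter is expected, and the estimated step of a 1.0-fold lower number from compound 2 to compound 3 (0.00 log units; within the scatter) is small. Compound 3 is expected at 14000 nM with an estimated range of 6000 nM to 30000 nM pending measurement.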

Compound 3, half-maximal inhibitory concentration: 15500 nM
Compound 3: middle estimate off by 1.1-fold (0.04 log units), on the low side; measured number inside the range.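

In this assay, replacing methylsulfanyl with hydrogen on an aromatic carbon, ortho to a large group, gives a 1.1-fold higher number from compound 2 to compound 3 (0.04 log units; within the scatter). For the compounds shown here, this pair is the first to read this position directly, and it does not separate 2-(methylsulfanyl)phenyl from phenyl on the shared core. Methylsulfanyl is therefore not needed at this position for a measurable number in this pair. Going by these compounds, whether an amine, a carboxylic acid or a longer chain at this position would shift the number remains open. Nothing given here bears on a cause for this step.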